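Chloro for Methoxy at Two Places on One Core

The source may hold more compounds than are shown below. What is called first, only, known or untested is meant among the compounds shown, and "the series" means these compounds.

Measured compounds:
Compound 1 `COc1ccc(NC(=O)C(=O)c2cn(C(C)C)c3c(Cl)cccc23)cn1` gives 10200 nM in a functional assay on FaDu cells (Homo sapiens) for cytotoxicity, read by MTT assay, with a stated time of 72 h; on this read-out lower numbers stand for higher toxicity in this test and higher numbers for lower toxicity in this test.
Compound 2 `COc1ccc(NC(=O)C(=O)c2cn(C(C)C)c3c(OC)cccc23)cn1` reaches only a limit, > 10000 nM.
Compound 3 `COc1ccc2c(C(=O)C(=O)Nc3ccc(OC)nc3)cn(C(C)C)c2c1` also reaches only a limit, > 10000 nM.

Compound 2 and compound 1 differ by chloro in place of methoxy on an aromatic carbon. The step that the limit leaves unreadable from compound 2 to compound 1 stays unreadable because of the limit of > 10000 nM in this assay, at which 2 of the 3 values shown sit. The cores of compound 2 and compound 3 differ in a way not broken down here. Compound 4 `COc1ccc(NC(=O)C(=O)c2cn(C(C)C)c3cc(Cl)ccc23)cn1` arises from compound 3 by chloro in place of methoxy on an aromatic carbon, the same kind of change as from compound 2 to compound 1, yet at a different place: meta to a fused ring and para to a fused ring, rather than ortho to a fused ring and meta to a fused ring. Compound 4 is expected to move by a step that the limit leaves unreadable from compound 3 to compound 4. This expectation rests on compound 1, which gives 10200 nM after the same kind of change. Compound 4 is therefore estimated at 11000 nM, between 5000 nM and 30000 nM.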

Compound 4, concentration lethal to 50% of the cells: 1770 nM
Compound 4: middle estimate off by 6.2-fold (0.79 log units), on the high side; measured number outside the range, below it.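

In this assay, chloro in place of methoxy on an aromatic carbon gives an at least 5.6-fold lower number from compound 3 to compound 4 (0.75 log units; beyond the scatter), a change beyond the scatter at this place on the core. The same kind of change on the core of compound 1 cannot be read, so the two steps cannot be compared in size, and carry-over from one core to the other is neither confirmed nor refuted: the limit of > 10000 nM in this assay, at which 2 of the 4 values shown sit. Compound 4 shows that the change can yield a readable drop at one place, not that a step of this size belongs to the change in general.

As far as these compounds go, whether an amine or a carboxylic acid on that same aromatic carbon would move the number in the same direction as chloro stays open. Also open, from the compounds shown here alone, is whether a longer chain in place of methoxy on the other ring would do so.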